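Working notes on four compounds and one reporter assay

The compounds below may be only part of what the source reports. "The series", "measured", "known", "first", "only" and "open" are said of these compounds alone.

Measured so far:
compound 1, `COc1cccc(/C=C/c2ccc(F)cc2)c1OC`, 2900 nM in an assay on HepG2 cells for activation of nuclear factor erythroid 2-related factor 2 (Homo sapiens), read by a luciferase reporter, with a stated time of 5 h; a higher number here means that more compound is needed for the effect, a lower number that less compound is needed
compound 2, `Fc1ccc(/C=C/c2ccccc2F)cc1F`, > 15000 nM in this assay
compound 3, `Fc1cccc(/C=C/c2ccccc2F)c1`, > 15000 nM in this assay

Among the measured compounds shown here, compound 1 gives the only number among the three values; in this assay compound 1 gives 2900 nM. The value of compound 2 is a limit of the assay. The value of compound 3 is likewise a limit. The change from compound 2 to compound 3 is hydrogen in place of fluoro on an aromatic carbon; its step, a step that the two limits leave unreadable from compound 2 to compound 3, cannot be read because of the limit of > 15000 nM in this assay, at which 2 of the 3 values shown sit.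

Compound 4, `COc1cccc(/C=C/c2ccccc2)c1OC`, is not yet measured. It differs from compound 1 by hydrogen in place of fluoro on an aromatic carbon. This is the same kind of change as that from compound 2 to compound 3, though not the same: there the place was ortho to a fluoro group (1 heavy atom) and para to a group of 9 heavy atoms, here it is para to a large group. The difference between the core of compound 1 and that of compound 2 is not broken down here.

For the measured compounds named here, the only measured example of the change gives no readable size, so the expectation for compound 4 rests on compound 1 alone, with its value 2900 nM, and on the scatter of the assay: the step from compound 1 to compound 4 is expected to be a 1.2-fold higher number from compound 1 to compound 4 (0.08 log units; within the scatter). In this assay compound 4 is estimated at 3500 nM, expected between 1200 nM and 10000 nM.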

Compound 4, half-maximal effective concentration: 4700 nM
Compound 4: the middle estimate sits 1.3-fold (0.13 log units) below what was measured, and the stated range covers the measured number.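

In this assay, hydrogen in place of fluoro on an aromatic carbon, para to a large group, gives a 1.6-fold higher number from compound 1 to compound 4 (0.21 log units; within the scatter), so on the core of compound 1 this change has no effect that can be told apart from repeat measurements. The same kind of change on the core of compound 2 cannot be read, because both values of that step are limits of the assay and not numbers: the limit of > 15000 nM in this assay, at which 2 of the 4 values shown sit. Whether the result carries from one core to the other is therefore not shown, as the one readable case stands alone and the place on the ring also differs between the two cases.

Left open is how the core of compound 1 responds when a group other than fluoro or hydrogen stands at that place, such as an amine or a carboxylic acid. No pair shown isolates the methoxy groups either, so the effect of replacing one with a hydroxyl or a longer chain remains open.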